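A Methyl Group Added to a Weakly Cytotoxic Core

The source may report more compounds than this note shows. Statements on the series, on what has been measured and on what is new or still open speak of the compounds shown alone.

Compound 1 `C[C@H]1CC[C@@H]2[C@@H](OC(=O)[C@]23CC(c2ccccc2)=NO3)[C@]2(C)C(=O)C=C[C@@]12O` is measured in a functional assay on SW-620 cells (Homo sapiens) for cytotoxicity, read by sulforhodamine B assay, with a stated time of 48 h (on this read-out lower numbers stand for stronger inhibition and higher numbers for weaker inhibition), where compound 1 gives 45400 nM. That number is the second highest of the three, close to compound 3 `C[C@H]1CC[C@@H]2[C@@H](OC(=O)[C@]23CC(c2cccc([N+](=O)[O-])c2)=NO3)[C@]2(C)C(=O)C=C[C@@]12O` with 49000 nM and far from compound 2 `C[C@H]1CC[C@@H]2[C@@H](OC(=O)[C@]23CC(c2ccccc2F)=NO3)[C@]2(C)C(=O)C=C[C@@]12O` with 11000 nM. Compound 4 `Cc1cccc(C2=NO[C@]3(C2)C(=O)O[C@@H]2[C@H]3CC[C@H](C)[C@]3(O)C=CC(=O)[C@@]23C)c1` differs from compound 1 by methyl in place of hydrogen on an aromatic carbon. Among the compounds with values here, two measured steps bear on this change: a 4.1-fold lower number from compound 1 to compound 2 (0.62 log units; beyond the scatter), and a 1.1-fold higher number from compound 1 to compound 3 (0.03 log units; within the scatter). One single-atom replacement on the same ring gave a modest gain, the other no change beyond the scatter. For a methyl group, only a small shift is expected, with no clear direction. Compound 4 is therefore estimated at 35000 nM, in a range from 12000 nM to 90000 nM, which corresponds to an expected 1.3-fold lower number from compound 1 to compound 4 (0.11 log units; within the scatter).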

Compound 4, half-maximal inhibitory concentration: 15000 nM
Beside the measured number, compound 4's estimate is 2.3-fold (0.37 log units) above it; the measured number falls inside the stated range.
By their numbers in this assay, from the lowest: compounds 2 and 4 (each within the scatter of the next); then compounds 1 and 3 (each within the scatter of the next).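

Adding one methyl group to the phenyl ring, meta to a large group, gives a 3.0-fold lower number from compound 1 to compound 4 (0.48 log units; beyond the scatter) and so moves the number beyond the scatter. Methyl in place of nitro gives a 3.3-fold lower number from compound 3 to compound 4 (0.51 log units; beyond the scatter) while 3-methylphenyl in place of 2-fluorophenyl gives a 1.4-fold higher number from compound 2 to compound 4 (0.13 log units; within the scatter) and leaves those two level, so a gain is no longer seen with fluoro alone. Nothing measured here explains these shifts.

On these data alone, whether a longer chain such as ethyl or an amine on the same ring would match the methyl group remains open.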